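Methyl on the anilino ring of the shared core

The compounds below may be only part of what the source reports. "The series", "measured", "known", "first", "only" and "open" are said of these compounds alone.

Measured compounds:
compound 1 `O=C(CSc1nc(Nc2ccccc2)c2ccccc2n1)Nc1ccccc1Cl`, a functional assay on NCI-H1975 cells (Homo sapiens) for inhibition, read by MTT assay, with a stated time of 72 h; on this read-out lower numbers stand for stronger inhibition and higher numbers for weaker inhibition: 9610 nM
compound 2 `C=CC(=O)Nc1cccc(NC(=O)CSc2nc(Nc3ccccc3)c3ccccc3n2)c1`, this assay: 8120 nM

Among the compounds with values here, compound 2 holds the lower of the two numbers, yet the only step in the set, a 1.2-fold lower number from compound 1 to compound 2 (0.07 log units; within the scatter), lies within the scatter, so neither compound stands apart from the other in this assay.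

Compound 3 `C=CC(=O)Nc1cccc(NC(=O)CSc2nc(Nc3ccccc3C)c3ccccc3n2)c1` keeps the whole of compound 2 and differs in one place: methyl in place of hydrogen on an aromatic carbon. One bond further out the change reads anilino to (2-methylphenyl)amino. Within the data shown here, no measured step touches this ring; the single known step alters the group on the amide-type nitrogen and is within the scatter, so it offers no guide of its own to a methyl in place of hydrogen on the anilino side.

For compound 3 no step beyond the scatter is expected, a 1.0-fold lower number from compound 2 to compound 3 (0.01 log units; within the scatter). Compound 3 is estimated at 8000 nM, within 3000 nM to 20000 nM.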

Compound 3, half-maximal inhibitory concentration: 9920 nM
Compound 3: the middle estimate sits 1.2-fold (0.09 log units) below what was measured; the measured number falls inside the stated range.
By their numbers in this assay, from the lowest: compounds 2, 1 and 3 (each within the scatter of the next).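

Within the data shown here, replacing anilino with (2-methylphenyl)amino gives the first reading on this ring of the shared core. In this assay the change stays small (a 1.2-fold higher number from compound 2 to compound 3 (0.09 log units; within the scatter)), so methyl on this aromatic carbon, ortho to a large group, does not set compound 3 apart from compound 2. No evidence at hand bears on this result.

Going by these compounds, whether another group at this place, such as methoxy, an amine or a carboxylic acid, would move the number beyond the scatter stays open. Also open, on these data alone, is whether a longer chain, such as ethyl or propyl, in place of the methyl would read any differently from compound 3.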